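The compounds below may be only part of what the source reports. "The series", "measured", "known", "first", "only" and "open" are said of these compounds alone.

Working notes on the series, read in a functional assay on MCF7 cells (Homo sapiens) for inhibition, read by MTT assay, with a stated time of 72 h; a higher number here means a weaker inhibitor, a lower number a stronger inhibitor. Compound 1 `Cc1cc(Nc2cc(-c3ccccc3)[nH]n2)n2nc(SCC3CCCCC3)nc2n1` gives > 50000 nM, a limit of the assay and not a number. Compound 2 `Cc1cc(Nc2cc(-c3ccccc3)[nH]n2)n2nc(SCc3ccc(Br)cc3)nc2n1` gives 2720 nM. Compound 3 `Cc1cc(Nc2cc(-c3ccccc3)[nH]n2)n2nc(SCCCc3ccccc3)nc2n1` gives 3900 nM, within the scatter of compound 2. Compound 4 `Cc1cc(Nc2cc(-c3ccccc3)[nH]n2)n2nc(SCc3ccc(C(F)(F)F)cc3)nc2n1` changes compound 3 as follows: 4-(trifluoromethyl)phenyl in place of phenethyl on a saturated chain carbon bound to a sulfur. The entering group keeps the six-membered aromatic ring of carbon only. Leaving cyclohexyl gave two large steps, an at least 18-fold lower number from compound 1 to compound 2 (1.26 log units; beyond the scatter) and an at least 12-fold lower number from compound 1 to compound 3 (1.10 log units; beyond the scatter). Phenethyl in place of 4-bromophenyl gave only a 1.4-fold higher number from compound 2 to compound 3 (0.16 log units; within the scatter). No step beyond the scatter is therefore expected in this assay. The expected step is a 1.3-fold lower number from compound 3 to compound 4 (0.11 log units; within the scatter). The estimate for compound 4 is 3000 nM, with an expected range of 1200 nM to 8000 nM.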

Compound 4, half-maximal inhibitory concentration: 4820 nM
The estimate for compound 4 lay 1.6-fold (0.21 log units) below the measured number; low and high end bracket the measured number.
By their numbers in this assay, from the lowest: compounds 2, 3 and 4 (each within the scatter of the next). At a limit, above all of these: compound 1.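

In this assay, replacing phenethyl with 4-(trifluoromethyl)phenyl gives a 1.2-fold higher number from compound 3 to compound 4 (0.09 log units; within the scatter), and trifluoromethyl in place of bromo on an aromatic carbon gives a 1.8-fold higher number from compound 2 to compound 4 (0.25 log units; within the scatter), so neither change separates these compounds. A third group with a six-membered aromatic ring of carbon only also stands clear of cyclohexyl, with an at least 10-fold lower number from compound 1 to compound 4 (1.01 log units; beyond the scatter). That step rests on a limit of the assay and not a number: the limit of > 50000 nM in this assay, at which 1 of the 4 values shown sits.

On these data alone, it remains open whether an amine or a carboxylic acid on the aromatic ring would move the number beyond the scatter. As far as these compounds go, a longer chain or a cyclopentyl group at this place also remains open.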